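The source may hold more compounds than are shown below. What is called first, only, known or untested is meant among the compounds shown, and "the series" means these compounds.

For the measured compounds named here, in an ADME assay on HEK293 cells (Homo sapiens) for cytotoxicity, read by resazurin assay, with a stated time of 72 h (a higher number here means that more compound is tolerated, a lower number that less compound is tolerated), only two compounds have been measured so far. Compound 1 `COc1cccc(CNC(=O)c2nc3ccc(F)c(OCCc4ccc(N)cc4)c3c(=O)[nH]2)c1` gives > 20000 nM, which is a limit and not a number. Compound 2 `COc1cc(CNC(=O)c2nc3ccc(F)c(OCCc4ccc(C(=O)O)cc4)c3c(=O)[nH]2)ccc1F` gives > 20000 nM, which is likewise a limit. Going by the values given here, compound 2 therefore has no number of its own and stands with the only other compound tested: the limit of > 20000 nM in this assay, at which 2 of the 2 values shown sit.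

Compound 3 `O=C(O)c1ccc(CCOc2c(F)ccc3nc(C(=O)NCc4cccc(OCC5CC5)c4)[nH]c(=O)c23)cc1` carries 3-(cyclopropylmethoxy)phenyl in place of 4-fluoro-3-methoxyphenyl on a saturated chain carbon bound to an amide-type nitrogen. Among the compounds with values here, no measured pair shows what a change at this place does in this assay. The expectation rests on compound 2, which reads > 20000 nM, a limit. The estimated a number no higher from compound 2 to compound 3 (the limit leaves the size open) is expected to stay within the scatter, in neither direction. For compound 3, the expected half-maximal cytotoxic concentration is 20000 nM, with an estimated range from 10000 nM to 40000 nM.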

Compound 3, half-maximal cytotoxic concentration: > 20000 nM
Compound 3 gave a limit, no number; the forecaster's own chance of this, stated with the estimate: 75%; the middle value sits exactly at the limit.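

In this assay compound 3 gives > 20000 nM, a limit and not a number. No step can be read between compound 2 and compound 3, which share one reading: the limit of > 20000 nM in this assay, at which 3 of the 3 values shown sit.

The compounds shown leave open at what concentration any of them becomes cytotoxic.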